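A few compounds are considered here, and "the series" means these few. Any claim that something is new, unique, unknown or untested is made for them only; others in the source may bear on it.

Measured so far in an assay on HeLa cells for displacement of a labelled ligand from adenosine receptor A3 (Homo sapiens), with a stated time of 180 min, tested at 1 uM; a higher number here means more inhibition at the concentration tested (going by the name of the read-out), a lower number less inhibition:
compound 1 `CC1=C(C(=O)OC(C)C)C(C2CCCC2)N/C(=N/C#N)N1`, 3%
compound 2 `CCOC(=O)C1=C(C)N/C(=N\C#N)NC1c1ccco1`, 20%
compound 3 `CCOC(=O)C1=C(C)N/C(=N\C#N)NC1c1ccccc1`, 13%

Compound 3 stands second highest of the three numbers. Its nearest neighbour is compound 2, and the step of a number 7 percentage points lower from compound 2 to compound 3 (within the scatter) lies within the scatter, so no order between the two is claimed. Furthest from it is compound 1, which gives 3%.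

Compound 4 `CCOC(=O)C1=C(C)N/C(=N\C#N)NC1C1CCCC1` is not yet measured and differs from compound 3 by cyclopentyl in place of phenyl on a saturated ring carbon. Going by the values given here, the only measured single step, a number 7 percentage points lower from compound 2 to compound 3 (within the scatter), changes the group on the same saturated ring carbon and stays within the scatter, but it exchanges two aromatic rings and says little about a cyclopentyl. Compound 1 also carries a cyclopentyl on a saturated ring carbon and differs from compound 4 only in its ester group. In this assay, among the compounds with values here, compound 1 gives 3%, and no single step links compound 1 to compound 3 or compound 4. A low number is therefore expected for compound 4. Compound 4 is estimated at 6%, within -5% to 18%. The expected step of a number 7 percentage points lower from compound 3 to compound 4 (within the scatter) would be a small fall, not beyond the scatter.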

Compound 4, a percentage reported as inhibition, at one concentration (the size of the read-out at that concentration, not a potency): 4%
Estimate against measurement, compound 4: 2 percentage points above, within the range that was stated.
By their numbers in this assay, from the lowest: compounds 1, 4, 3 and 2 (each within the scatter of the next, the first and the last beyond it).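

Going by these compounds alone, on the saturated ring carbon, cyclopentyl gives a number 9 percentage points lower from compound 3 to compound 4 (within the scatter) and so is not separated from phenyl, yet it gives a number 16 percentage points lower from compound 2 to compound 4 (beyond the scatter) and this is the first single-place step to clear the scatter. Changing the ester group with cyclopentyl in place gives a number 1 percentage points higher from compound 1 to compound 4 (within the scatter) and shows no separation. No measured property is available to account for these numbers.

Going by these compounds, whether an amine or a carboxylic acid on this ring carbon would raise the number remains open. So does the effect of a longer chain in place of the ethoxycarbonyl group.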